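Trimming the amide to a primary carbamoyl group

The source may hold more compounds than are shown below. What is called first, only, known or untested is meant among the compounds shown, and "the series" means these compounds.

Measured compounds:
compound 1, `CC(C)NC(=O)c1ccc2cc(C(O)(c3c[nH]cn3)C(C)C)ccc2c1`: 12 nM
compound 2, `CC(=O)c1ccc2cc(C(O)(c3c[nH]cn3)C(C)C)ccc2c1`: 14 nM
compound 3, `CCCNC(=O)c1ccc2cc(C(O)(c3c[nH]cn3)C(C)C)ccc2c1`: 13 nM

All three share one core and were tested in an assay on microsomes from Testis (strain Sprague-Dawley) for inhibition of steroid 17-alpha-hydroxylase/17,20 lyase (Rattus norvegicus); on this read-out higher numbers stand for weaker inhibition and lower numbers for stronger inhibition. Compound 3 holds the second highest of the three numbers, yet its gap to compound 2 and its gap to compound 1 both fall within the scatter, so the three compounds cannot be told apart on this read-out.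

Compound 4, `CC(C)C(O)(c1ccc2cc(C(N)=O)ccc2c1)c1c[nH]cn1`, has not yet been measured. It differs from compound 3 in one place: hydrogen in place of propyl on an amide-type nitrogen. Among the compounds with values here, two measured steps bear on this change. Swapping the group on the amide nitrogen, a 1.1-fold higher number from compound 1 to compound 3 (0.03 log units; within the scatter), left the number unchanged. Exchanging the whole amine side of the carbonyl for methyl, a 1.2-fold higher number from compound 1 to compound 2 (0.07 log units; within the scatter), and the reverse move, a 1.1-fold lower number from compound 2 to compound 3 (0.03 log units; within the scatter), also stayed within the scatter. Within the data shown here, nothing measured so far reacts to what sits on the amide nitrogen, so for compound 4 a step of a 1.1-fold higher number from compound 3 to compound 4 (0.03 log units; within the scatter) is expected, that is, none beyond the scatter. Compound 4 is therefore estimated at 14 nM, with a range from 6 nM to 35 nM.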

Compound 4, half-maximal inhibitory concentration: < 10 nM
Compound 4: no number, only a limit; the forecaster's own chance of this, stated with the estimate: 2%; at least 1.4-fold (0.14 log units) between middle value and limit.
By their numbers in this assay, from the lowest: compounds 1, 3 and 2 (each within the scatter of the next). At a limit, below all of these: compound 4.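

In this assay compound 4 gives < 10 nM, which is a limit of the assay and not a number. Even so, the limit shows that hydrogen on the amide-type nitrogen does not raise the number, with steps of an at least 1.3-fold lower number from compound 3 to compound 4 (0.11 log units; that floor lies within the scatter), an at least 1.4-fold lower number from compound 2 to compound 4 (0.14 log units; that floor lies within the scatter) and an at least 1.2-fold lower number from compound 1 to compound 4 (0.07 log units; that floor lies within the scatter). The earlier compounds shown here compared only propyl with isopropyl on this nitrogen and methyl with an amine side on the carbonyl carbon, whereas compound 4 shows that the chain can be removed altogether without losing inhibition, although each floor lies within the scatter and so no real gain can be claimed.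

On these data alone, how far the true number of compound 4 lies under its limit stays open. So does whether a longer chain such as hexyl on this nitrogen, or a carboxylic acid in place of the carbamoyl group, would keep the number this low.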